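This account rests on a few compounds, and the source may have more. Where it says the series, first, only, none or still open, it means among the compounds named here.

Of the compounds shown here, three sharing one core have been measured in a functional assay on the whole organism (B cells) with Mus musculus as the target; a lower number here means a smaller maximal response, a higher number a larger maximal response. Compound 1 `Nc1nc(O)c2c(n1)n(C1OC(CO)[C@@H](O)[C@H]1O)c(=O)n2C/C=C/c1ccccc1` gives 73% in this assay and stands highest among the three. Compound 2 `Cn1c(=O)n(C2OC(CI)[C@@H](O)[C@H]2O)c2nc(N)nc(O)c21` gives 32%, a number beyond the usual scatter below compound 1, and compound 3 `C=CCn1c(=O)n(CCCCO)c2nc(N)nc(O)c21` gives 12%, still further below. No pair among these three differs in only one place, so no single change can be read from them on its own; the numbers show only that compound 1 sits well above the other two.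

Compound 4 `CCCCn1c(=O)n(C2OC(CO)[C@@H](O)[C@H]2O)c2nc(N)nc(O)c21` has not yet been measured. It differs from compound 1 in one place: propyl in place of 2-phenylethenyl on a saturated chain carbon bound to an aromatic nitrogen. Compound 2 and compound 3 each carry a different group at that same place and also differ from compound 1 elsewhere, so the comparison is loose, yet both of them give the lower numbers in this assay. On that basis the step in this assay is expected to run downward, beyond the scatter, and is estimated at a number 31 percentage points lower from compound 1 to compound 4 (beyond the scatter). Compound 4 is expected to reach about 42% in this assay, with a likely range from 20% to 65%.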

Compound 4, largest response reached (reported as maximal response), in percent of the reference or control that the assay uses: 86%
For compound 4 the middle estimate is 44 percentage points below the measured one, and the stated range ends below it.
By their numbers in this assay, from the lowest: compound 3; then compound 2; then compound 1; then compound 4.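

In this assay, the aromatic ring and the double bond of 2-phenylethenyl prove unnecessary for a high maximal response at this place on the shared core: swapping that group for propyl, on a saturated chain carbon bound to an aromatic nitrogen, gives a number 13 percentage points higher from compound 1 to compound 4 (beyond the scatter) and not a loss. Among the compounds shown here, this is the first comparison here that changes one place only, and it shows that a plain alkyl group with no ring, and with fewer heavy atoms, can go with a higher number than the larger group it replaces. Nothing available explains why the response rises with this change.

Going by these compounds, whether the step comes from losing the aromatic ring, losing the double bond or shortening the group stays open, and a 3-phenylpropyl group, which keeps the ring without the double bond, would help to separate these. On these data alone, it is also open how a longer chain such as hexyl, or a chain ending in an amine, would behave at this place, and whether the rise from propyl holds on the other sugar-like or open-chain groups seen in compound 2 and compound 3.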